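The source may hold more compounds than are shown below. What is called first, only, known or untested is meant among the compounds shown, and "the series" means these compounds.

Of the compounds shown here, three have been measured so far in an in vitro ADME assay on microsomes from liver (Mus musculus) for pharmacokinetics, read by LC-MS, with a stated time of 10 min, tested at 1 uM (on this read-out higher numbers stand for fast clearance and lower numbers for slow clearance), on the shared core: compound 1 `COc1ccc(NC(=O)[C@H]2CN(C)C[C@@H]2c2ccc(/C=C/C(=O)Nc3ccccc3N)cc2)cc1` gives 54 mL/min/kg and compound 2 `COc1cccc(NC(=O)[C@H]2CN(C)C[C@@H]2c2ccc(/C=C/C(=O)Nc3ccccc3N)cc2)c1` gives 65 mL/min/kg while compound 3 `CN1C[C@H](C(=O)Nc2ccc(F)c(Cl)c2)[C@@H](c2ccc(/C=C/C(=O)Nc3ccccc3N)cc2)C1` gives 34 mL/min/kg in the same test. Compound 3 stands within the scatter of both others, with a 1.6-fold lower number from compound 1 to compound 3 (0.20 log units; within the scatter) and a 1.9-fold lower number from compound 2 to compound 3 (0.28 log units; within the scatter) as its steps. Compound 4 `CN1C[C@H](C(=O)Nc2ccc(Cl)c(Cl)c2)[C@@H](c2ccc(/C=C/C(=O)Nc3ccccc3N)cc2)C1` differs from compound 3 by chloro in place of fluoro on an aromatic carbon and nothing else, chloro in place of fluoro on an aromatic carbon. For the measured compounds named here, no measured step makes this exchange. The closest steps change the group on the same amide-type nitrogen, and even a 1.9-fold lower number from compound 2 to compound 3 (0.28 log units; within the scatter) stays within the scatter. No step beyond the scatter is therefore expected in this assay here. The expected step is a 1.1-fold higher number from compound 3 to compound 4 (0.02 log units; within the scatter) in size. For compound 4 the estimated clearance is 36 mL/min/kg with an expected range of 20 mL/min/kg to 62 mL/min/kg in this test.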

Compound 4, clearance: 36 mL/min/kg
Estimate against measurement, compound 4: no gap at the digits printed; the range from low to high includes it.
By their numbers in this assay, from the lowest: compounds 3, 4, 1 and 2 (each within the scatter of the next).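

In this assay, for the compounds shown here, chloro in place of fluoro at this place, ortho to a chloro group and para to a large group, gives a 1.1-fold higher number from compound 3 to compound 4 (0.02 log units; within the scatter) and is the first measured exchange of this single atom. The 3,4-dichlorophenyl group also stays level with both methoxyphenyl groups, with a 1.8-fold lower number from compound 2 to compound 4 (0.26 log units; within the scatter) and with a 1.5-fold lower number from compound 1 to compound 4 (0.18 log units; within the scatter) as the steps. Nothing available bears on what lies behind these numbers. On these data alone, whether an amine or a carboxylic acid at this place would give a step beyond the scatter remains open.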